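This account rests on a few compounds, and the source may have more. Where it says the series, first, only, none or still open, it means among the compounds named here.

Compound 1 `CN1CCN(c2cc(OCc3cc(F)c(Oc4ccc(Cl)c(C(F)(F)F)c4)c(F)c3)nc(=O)n2C)CC1`: 65.5 mL/min/kg
Compound 2 `COC1CCN(c2cc(OCc3cc(F)c(Oc4ccc(Cl)c(C(F)(F)F)c4)c(F)c3)nc(=O)n2C)CC1`: 20.9 mL/min/kg

Both compounds were tested in an ADME assay on S9 fraction from liver (Homo sapiens) for metabolic stability, tested at 0.1 uM; a lower number here means slower removal, a higher number faster removal of the compound. Compound 2 has the lower of the two numbers, at 20.9 mL/min/kg. For the measured compounds named here, the only measured step is a 3.1-fold lower number from compound 1 to compound 2 (0.50 log units; beyond the scatter), a modest one, and it comes with 4-methoxypiperidin-1-yl in place of 4-methylpiperazin-1-yl on an aromatic carbon.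

Compound 3 `Cn1c(N2CCN(C3CC3)CC2)cc(OCc2cc(F)c(Oc3ccc(Cl)c(C(F)(F)F)c3)c(F)c2)nc1=O` differs from compound 2 by one change: 4-cyclopropylpiperazin-1-yl in place of 4-methoxypiperidin-1-yl on an aromatic carbon. In words, 4-cyclopropylpiperazin-1-yl stands in place of 4-methoxypiperidin-1-yl on an aromatic carbon. The entering group is again a piperazine ring, now with cyclopropyl where compound 1 has methyl, so the measured step can be read roughly in reverse. Going by the values given here, no measurement yet isolates the swap of methyl for cyclopropyl, which makes this only a partial guide. Among the compounds with values here, with a 3.1-fold lower number from compound 1 to compound 2 (0.50 log units; beyond the scatter) as the sole evidence, a rise of somewhat smaller size is expected, and the estimated step is a 2.2-fold higher number from compound 2 to compound 3 (0.33 log units; beyond the scatter). For compound 3 the expected clearance is 45 mL/min/kg, with an estimated range of 20 mL/min/kg to 95 mL/min/kg.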

Compound 3, clearance: 3.26 mL/min/kg
Compound 3: middle estimate off by 14-fold (1.14 log units), on the high side; the measured number lies below the stated range.
By their numbers in this assay, from the lowest: compound 3; then compound 2; then compound 1.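

In this assay, the group carried on the piperazine nitrogen turns out to matter a great deal: cyclopropyl in place of methyl on an amine nitrogen in a ring gives a 20-fold lower number from compound 1 to compound 3 (1.30 log units; beyond the scatter), a large step at a single site in an otherwise unchanged molecule. The earlier pair could have suggested that a piperazine at this position simply goes with a higher number than 4-methoxypiperidin-1-yl, but a 6.4-fold lower number from compound 2 to compound 3 (0.81 log units; beyond the scatter), so the ring alone does not set the outcome: with methyl on its nitrogen the piperazine compound stands above compound 2, and with cyclopropyl it stands below. Nothing available explains why cyclopropyl and methyl differ so widely here.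

The compounds shown leave open whether the low number is particular to cyclopropyl or would also appear with an ethyl, isopropyl or cyclobutyl group on that nitrogen. On these data alone, it is also open how a piperazine with only the amine hydrogen at that nitrogen, or one bearing an acetyl group, would compare.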